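Series notes: thioether and imidazole variants on a shared core

The compounds below may be only part of what the source reports. "The series", "measured", "known", "first", "only" and "open" are said of these compounds alone.

Measured so far:
compound 1, `Cc1cc(-n2ccnc2)cn2c(CSCCc3ccccc3)cnc12`: 100 ug/mL
compound 2, `Cc1cc(Sc2ccc(Cl)cc2)cn2c(CSCCc3ccccc3)cnc12`: 20 ug/mL

Among the measured compounds shown here, in an ADME assay on HEL cells (Homo sapiens) for cytotoxicity, with a stated time of 3 days (a higher number here means that more compound is tolerated, a lower number that less compound is tolerated), compound 2 gives the lowest of the two numbers; the only neighbour is compound 1, and the single measured step is a 5.0-fold lower number from compound 1 to compound 2 (0.70 log units; beyond the scatter), a modest change that follows the exchange of one whole ring substituent for another. Compound 3, `Cc1cc(Sc2ccc(O)cc2)cn2c(CSCCc3ccccc3)cnc12`, has not been measured. Its difference from compound 2 is hydroxy in place of chloro on an aromatic carbon. For the measured compounds named here, no measured step covers this exchange: the one step available replaces the entire (4-chlorophenyl)sulfanyl group with 1H-imidazol-1-yl, so it bears only loosely on a change of one heavy atom within that group. With nothing closer to go on, the step in this assay from compound 2 to compound 3 is expected to stay near or within the scatter, a 1.8-fold higher number from compound 2 to compound 3 (0.24 log units; within the scatter). Compound 3 is therefore estimated at 35 ug/mL, with a range from 15 ug/mL to 100 ug/mL.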

Compound 3, minimum cytotoxic concentration: 4 ug/mL
For compound 3 the middle estimate is 8.8-fold (0.94 log units) above the measured one; measured number below the stated range.
By their numbers in this assay, from the lowest: compound 3; then compound 2; then compound 1.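

In this assay the exchange of hydroxy for chloro on an aromatic carbon, para to a large group, gives a 5.0-fold lower number from compound 2 to compound 3 (0.70 log units; beyond the scatter) and so counts as a real change. A swap of one heavy atom at this position therefore moves the number beyond the scatter, which the earlier whole-group exchange could not show. The full replacement of 1H-imidazol-1-yl by (4-hydroxyphenyl)sulfanyl gives a 25-fold lower number from compound 1 to compound 3 (1.40 log units; beyond the scatter) as the largest step in the series, and no measurement here bears on the reason for either step.

Open, from the compounds shown here alone, is whether an amine, a methoxy group or a carboxylic acid at this position would fall with hydroxy or stay nearer chloro. Also open, going by these compounds, is whether the hydroxy-for-chloro step keeps its size when the phenylethyl thioether side of the shared core is changed.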